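Sulfoxide aryl swap on a nitroanilide scaffold

This account rests on a few compounds, and the source may have more. Where it says the series, first, only, none or still open, it means among the compounds named here.

Compound 2 `CC(O)(C[S+]([O-])c1ccc(F)cc1F)C(=O)Nc1ccc([N+](=O)[O-])cc1C(F)(F)F` gives only a limit in a functional assay on DU-145 cells (Homo sapiens) for antiproliferative activity (on this read-out higher numbers stand for weaker inhibition and lower numbers for stronger inhibition), namely > 100000 nM. Compound 1 `CC(O)(C[S+]([O-])c1ccc(C(F)(F)F)cn1)C(=O)Nc1ccc([N+](=O)[O-])cc1C(F)(F)F` is recorded in this assay with two entries, shown together as > 100000 nM; > 100000 nM (2 entries). Compound 3 `CC(O)(C[S+]([O-])c1ccccn1)C(=O)Nc1ccc(C#N)c(C(F)(F)F)c1` likewise stops at a limit, > 100000 nM. Compound 2 is therefore hard to place: its own value is a limit, one further value is a limit, and one further entry carries no single number, so the set shows the limit of > 100000 nM in this assay, at which 2 of the 3 values shown sit, rather than any ranking. Compound 4 `CC(O)(C[S+]([O-])c1ccccn1)C(=O)Nc1ccc([N+](=O)[O-])cc1C(F)(F)F` differs from compound 2 by pyridin-2-yl in place of 2,4-difluorophenyl on a sulfur. Among the measured compounds shown here, no measured step exists for this change. The step of a number no higher from compound 2 to compound 4 (the limit leaves the size open) is expected to amount to none beyond the scatter, leaving compound 4 at the limit. The estimate for compound 4 is 100000 nM, between 30000 nM and 300000 nM.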

Compound 4, half-maximal inhibitory concentration: > 100000 nM
Compound 4: a limit, no number; the forecaster's own chance of this, stated with the estimate: 85%; the middle value lies on the limit itself.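

Compound 2 and compound 4 both stop at a limit in this assay, so no step can be read between them: the limit of > 100000 nM in this assay, at which 3 of the 4 values shown sit.

The compounds shown leave open how pyridin-2-yl and 2,4-difluorophenyl on a sulfur compare in this assay.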